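Series notes: fluoro for 1-methylethenyl on the aryl ring of compound 1

The source may report more compounds than this note shows. Statements on the series, on what has been measured and on what is new or still open speak of the compounds shown alone.

Measured compounds

compound 1, `C=C(C)c1ccc(N2CCN(C(=O)c3oc(C)nc3-c3ccccc3)CC2)cc1`: "not active" (no number reported) in a functional assay on HL-60 cells (Homo sapiens) for inhibition, read by MTT assay, with a stated time of 72 h; on this read-out higher numbers stand for weaker inhibition and lower numbers for stronger inhibition
compound 2, `Cc1ccc(C)c(N2CCN(C(=O)c3oc(C)nc3-c3ccccc3F)CC2)c1`: 319 nM in this assay

Compound 1 stands without a number: in this assay compound 1 is reported as "not active" (no number reported), so no inhibitory concentration is fixed for it. Going by the values given here, compound 2 differs from compound 1 in more than one place and no step links the two; of that pair only the two values can be set side by side, and compound 2 gives 319 nM.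

Compound 3, `Cc1nc(-c2ccccc2)c(C(=O)N2CCN(c3ccc(F)cc3)CC2)o1`, is not yet measured. It follows from compound 1 by fluoro in place of 1-methylethenyl on an aromatic carbon. Among the compounds with values here, with compound 1 lacking a number, no step can be computed for this change; a step toward measurable inhibition is expected rather than none, since the smaller group enters where a three-carbon group leaves, though the size is open. Compound 3 is expected to give 3000 nM, within 400 nM to 25000 nM, with a real chance that only a limit is reported.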

Compound 3, half-maximal inhibitory concentration: > 1000 nM
Compound 3: a limit, no number (the forecaster's own chance of this, stated with the estimate: 40%); the middle value does not contradict the limit.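

No step can be read between compound 1 and compound 3, since in this assay compound 1 carries no number. Compound 3 gives > 1000 nM, a limit and not a number. From the compounds shown here alone, the size of any effect of fluoro replacing 1-methylethenyl remains open.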